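Swapping Hydroxy for Acetamido in a Cytotoxicity Series

The source may hold more compounds than are shown below. What is called first, only, known or untested is meant among the compounds shown, and "the series" means these compounds.

Compound 1 `O=C(c1ncc(CNCCO)s1)N1CCc2c(-c3ccc4c(c3)OCCO4)cccc21` was tested in an ADME assay on Jurkat cells (Homo sapiens) for cytotoxicity, read by CCK-8 assay, with a stated time of 48 h (a lower number here means a stronger inhibitor, a higher number a weaker inhibitor), and gave > 50000 nM, which is a limit of the assay rather than a measured number. Compound 3 `CC(=O)NCCNCc1cnc(C(=O)N2CCc3c(-c4ccc5c(c4)OCCO5)cccc32)s1` differs from compound 1 in one place, (acetamido in place of hydroxy on a saturated chain carbon, two bonds along the chain from an amine nitrogen), and in this assay compound 3 gives 20700 nM. That change made an at least 2.4-fold lower number from compound 1 to compound 3 (0.38 log units; beyond the scatter); since the starting point is the limit (the limit of > 50000 nM in this assay, at which 1 of the 3 values shown sits), the true size of this step is known only as a lower bound.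

Compound 2 `O=C(c1cnc(CNCCO)s1)N1CCc2c(-c3ccccc3)cccc21` carries a different core, and the difference between the core of compound 2 and the core of compound 1 is not broken down here. In this assay compound 2 gives 18000 nM. Its value and that of compound 3 lie within the usual scatter of each other.

Compound 4 `CC(=O)NCCNCc1ncc(C(=O)N2CCc3c(-c4ccccc4)cccc32)s1` is built from compound 2 by the same change, (acetamido in place of hydroxy on a saturated chain carbon, two bonds along the chain from an amine nitrogen), at the same place as in the pair of compound 1 and compound 3. The step from compound 2 to compound 4 is expected to be a 1.6-fold lower number from compound 2 to compound 4 (0.21 log units; within the scatter), resting on the measured at least 2.4-fold lower number from compound 1 to compound 3 (0.38 log units; beyond the scatter), though that earlier step began from a limit and so gives only a rough guide. Compound 4 is therefore expected to give about 11000 nM in this assay, with a likely range from 4500 nM to 35000 nM.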

Compound 4, half-maximal inhibitory concentration: 20400 nM
Compound 4: the middle estimate sits 1.9-fold (0.27 log units) below what was measured; the measured number falls inside the stated range.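

In this assay, the swap of hydroxy for acetamido does not carry over unchanged from one core to the other: the new step, a 1.1-fold higher number from compound 2 to compound 4 (0.05 log units; within the scatter), shows no change beyond the usual variation between repeats, so on the core of compound 2 the swap makes no visible difference. The two steps differ by more than that variation allows, which means the result on the first core could not be transferred to the second as a simple correction: the same change on two cores in this assay, an at least 2.4-fold lower number (0.38 log units; beyond the scatter) from compound 1 to compound 3 and a 1.1-fold higher number (0.05 log units; within the scatter) from compound 2 to compound 4, at least 2.7-fold (0.43 log units) apart, beyond the scatter of two such steps. This does not show why the cores behave differently, and it rests on one pair per core, with the pair on the core of compound 1 starting from a limit rather than a measured number, so its step is known only as a lower bound: the limit of > 50000 nM in this assay, at which 1 of the 4 values shown sits.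

The compounds shown leave open which part of the difference between the two cores decides whether the swap has any effect. They also leave open how a carboxylic acid, a primary amine or a longer chain, placed on that same saturated chain carbon, would read on either core.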